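The source may hold more compounds than are shown below. What is called first, only, known or untested is meant among the compounds shown, and "the series" means these compounds.

The measured compounds:
compound 1, `COc1cc(N/C=C\C(=O)c2cn(-c3ccccc3)nc2-c2ccccc2)cc(OC)c1OC`, with 5930 nM in a functional assay on PC-3 cells (Homo sapiens) for antiproliferative activity, read by MTT assay, with a stated time of 48 h; a lower number here means a stronger inhibitor, a higher number a weaker inhibitor;
compound 2, `O=C(/C=C\Nc1ccc(C(F)(F)F)cc1)c1cn(-c2ccccc2)nc1-c1ccc(F)cc1`, with > 50000 nM;
compound 3, `O=C(/C=C\Nc1ccc(O)cc1)c1cn(-c2ccccc2)nc1-c1ccc(Cl)cc1`, with 4430 nM.

Compound 1 has the highest of the two numbers. Its nearest neighbour is compound 3, which gives a number that is lower but within the scatter of compound 1, so no order between the two can be read. The value of compound 2 is a limit of the assay and not a number (the limit of > 50000 nM in this assay, at which 1 of the 3 values shown sits).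

The step to compound 4 leaves the aniline part of compound 1 untouched and changes the other aromatic ring: chloro in place of hydrogen on an aromatic carbon, on an aromatic carbon of a six-membered aromatic ring of carbon only, para to a large group. Compound 4 is `COc1cc(N/C=C\C(=O)c2cn(-c3ccccc3)nc2-c2ccc(Cl)cc2)cc(OC)c1OC`. Compound 3 already carries the same 4-chlorophenyl, with a different aniline, and sits close to compound 1. Compound 4 is therefore expected to give a number near that of compound 1, with the step of a 1.3-fold lower number from compound 1 to compound 4 (0.12 log units; within the scatter) not exceeding the scatter; the estimate for compound 4 is 4500 nM, between 1500 nM and 14000 nM.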

Compound 4, half-maximal inhibitory concentration: 9980 nM
Beside the measured number, compound 4's estimate is 2.2-fold (0.35 log units) below it; measured number inside the range.
By their numbers in this assay, from the lowest: compounds 3, 1 and 4 (each within the scatter of the next, the first and the last beyond it). At a limit, above all of these: compound 2.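

In this assay, among the compounds shown here, the pair of compound 1 and compound 4 gives the first direct reading of chloro in place of hydrogen on an aromatic carbon, para to a large group, with the aniline part held the same (a 1.7-fold higher number from compound 1 to compound 4 (0.23 log units; within the scatter)). Compound 3 also carries the 4-chlorophenyl, but with a different aniline part, and could not isolate this change. This single pair gives no sign that going from phenyl to 4-chlorophenyl moves the number beyond the scatter, and nothing measured here gives a cause for the step.

From the compounds shown here alone, whether a fluoro, a methoxy, an amine or a carboxylic acid on that carbon would read differently from chloro stays open, as does whether the step holds with another aniline part. For compound 2 the reading of > 50000 nM is a limit of the assay and not a number, and this compound differs from compound 1 in more than one place.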